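The source may hold more compounds than are shown below. What is called first, only, known or untested is meant among the compounds shown, and "the series" means these compounds.

Of the compounds shown here, three sharing one core have been measured in an ADME assay on microsomes from liver (Homo sapiens) for metabolic stability, tested at 2.5 uM; on this read-out lower numbers stand for slow clearance and higher numbers for fast clearance. Compound 1 `Cc1ccc(S(=O)(=O)c2cnc3c(F)cccc3c2-c2cccc(F)c2)cc1F` gives 3.92 mL/min in this assay, compound 2 `O=S(=O)(c1cc(Cl)cc(Cl)c1)c1cnc2c(F)cccc2c1-c1cccc(F)c1` gives 1.08 mL/min, and compound 3 `O=S(=O)(c1cc(Cl)cc(Cl)c1)c1cnc2c(F)cccc2c1-c1ccc(F)cc1` gives 1.01 mL/min. Compound 2 therefore sits second highest of the three numbers: its nearest neighbour is compound 3, and the two lie within the scatter of each other (a 1.1-fold lower number from compound 2 to compound 3 (0.03 log units; within the scatter)), while compound 1 stands further off, with a 3.6-fold lower number from compound 1 to compound 2 (0.56 log units; beyond the scatter).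

Compound 4 `O=S(=O)(c1cccc(F)c1)c1cnc2c(F)cccc2c1-c1cccc(F)c1` has not yet been measured. It differs from compound 2 in one place: 3-fluorophenyl in place of 3,5-dichlorophenyl on a sulfonyl sulfur.

Among the compounds with values here, the only measured step that touches the same place is the change on the sulfonyl sulfur between compound 1 and compound 2, which produced a 3.6-fold lower number from compound 1 to compound 2 (0.56 log units; beyond the scatter). Within the data shown here, that step shows that exchanging the group on the sulfonyl sulfur can move the number well beyond the scatter, but the group entering compound 4 is not the one present in compound 1, so the direction is uncertain. As the group that enters compound 4 resembles neither of the two groups already compared, a modest rise back toward compound 1 is expected in this assay, so compound 4 is estimated at 2 mL/min, with a range from 1 mL/min to 4 mL/min, corresponding to an expected step of a 1.9-fold higher number from compound 2 to compound 4 (0.27 log units; within the scatter).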

Compound 4, intrinsic clearance in a liver preparation (reported as CLH), per the amount of preparation that the assay uses: 1.14 mL/min
Estimate against measurement, compound 4: 1.8-fold (0.24 log units) above; low and high end bracket the measured number.
By their numbers in this assay, from the lowest: compounds 3, 2 and 4 (each within the scatter of the next); then compound 1.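

In this assay, exchanging the 3,5-dichlorophenyl on the sulfonyl sulfur for 3-fluorophenyl gives a 1.1-fold higher number from compound 2 to compound 4 (0.02 log units; within the scatter), so not every exchange at this position moves the number beyond the scatter, and these two groups cannot be told apart here. The new compound also allows a cleaner comparison than the earlier step, which changed the whole group at once: putting hydrogen in place of the methyl of the 3-fluoro-4-methylphenyl group, with nothing else altered, gives a 3.4-fold lower number from compound 1 to compound 4 (0.54 log units; beyond the scatter). Among compound 1, compound 2 and compound 4, which differ only in the group on the sulfonyl sulfur, the one group carrying a methyl is therefore the one that stands apart, with the higher number.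

No measurement shown here explains why this single methyl makes such a difference. On these data alone, it also remains open whether an ethyl or a methoxy in place of that methyl would stand with compound 1 or with compound 4, and whether a plain phenyl on the sulfonyl sulfur would stay level with the 3-fluorophenyl of compound 4.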